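The compounds below may be only part of what the source reports. "The series", "measured", "known", "first", "only" and "open" are said of these compounds alone.

Compound 1 `Fc1ccc(-c2nc3cnc(Nc4ccccn4)cc3[nH]2)cc1C(F)(F)F`: 64%
Compound 2 `FC(F)(F)c1ccc(Nc2cc3[nH]c(C4CCOC4)nc3cn2)nc1`: 67%

In an ADME assay on microsomes from liver (Mus musculus) for metabolic stability, read by LC-MS, with a stated time of 30 min, tested at 0.1 uM (a lower number here means that less of the compound is left, a higher number that more of the compound is left), compound 2 gives 67% and stands within the usual scatter of compound 1 at 64% so the two cannot be ranked. The next compound to be read is compound 3 `FC1(F)CCC(c2nc3cnc(Nc4ccc(C(F)(F)F)cn4)cc3[nH]2)CC1`, which carries 4,4-difluorocyclohexyl in place of oxolan-3-yl on an aromatic carbon. The group sits on the five-membered aromatic ring with 2 nitrogen, between two ring nitrogen atoms.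

For the measured compounds named here, no two measured compounds differ in one place only, so the series offers no measured step as a guide to this exchange. The direction below is a judgement on the structural change alone and not a trend in the data. A moderate fall in this assay is expected, one that may not stand far clear of the scatter. The estimated change is a number 15 percentage points lower from compound 2 to compound 3 (beyond the scatter) on this reading. For compound 3 the estimated value is 52% with an expected range from 32% to 72% and that range is kept wide.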

Compound 3, percent of the compound remaining: 73%
Estimate against measurement, compound 3: 21 percentage points below, and the stated range ends below it.
By their numbers in this assay, from the lowest: compounds 1, 2 and 3 (each within the scatter of the next).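

In this assay, for the compounds shown here, the exchange on an aromatic carbon between two ring nitrogen atoms gives a number 6 percentage points higher from compound 2 to compound 3 (within the scatter), the first measured step that differs in one place only. At this position, the read-out of percent remaining does not separate oxolan-3-yl, a five-membered ring with 1 hetero atom and 1 hydrogen-bond acceptor, from 4,4-difluorocyclohexyl, a six-membered ring of carbon only with 8 heavy atoms against 5 and 0 hydrogen-bond acceptors. No measurement at hand bears on the reason for this result.

Compound 1 differs from compound 2 and compound 3 in more than one place, so its group at this position cannot be compared with theirs, and this single step does not define a trend for the position. Still open, going by these compounds, is how this position would read with a basic amine such as piperidin-4-yl, a carboxylic acid, or an open alkyl chain in place of these rings, and whether the step would hold with other groups on the rest of the molecule.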